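Adding bromine to the strongest binder of the set

The source may report more compounds than this note shows. Statements on the series, on what has been measured and on what is new or still open speak of the compounds shown alone.

Measured in an assay on membranes from brain (Cavia porcellus) for binding affinity to Sigma non-opioid intracellular receptor 1 (Homo sapiens), read by radioligand binding; a higher number here means a weaker inhibitor, a lower number a stronger inhibitor:
Compound 1, `O=C(Cc1ccccn1)NC1CCN(Cc2ccccc2)CC1`: 236 nM
Compound 2, `O=C(Cc1cccnc1)NC1CCN(Cc2ccccc2)CC1`: 269 nM
Compound 3, `O=C(Cc1c[nH]c2ccccc12)NC1CCN(Cc2ccccc2)CC1`: 10.9 nM

Compound 3 stands lowest of the three numbers; compound 1 and compound 2 sit far higher, and the gap between them, a 1.1-fold higher number from compound 1 to compound 2 (0.06 log units; within the scatter), is within the scatter. Compound 4, `O=C(Cc1c[nH]c2ccc(Br)cc12)NC1CCN(Cc2ccccc2)CC1`, is compound 3 with one change: bromo in place of hydrogen on an aromatic carbon. Among the measured compounds shown here, none of the measured steps touches this ring, so no measured step bears on the change; the only comparison is the value of compound 3 itself. A step of a 1.4-fold lower number from compound 3 to compound 4 (0.13 log units; within the scatter) is therefore expected, within the scatter. Compound 4 is estimated to give 8 nM in this assay, with a range from 3 nM to 25 nM.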

Compound 4, inhibition constant: 51.9 nM
For compound 4 the middle estimate is 6.5-fold (0.81 log units) below the measured one; measured number outside the range, above it.
By their numbers in this assay, from the lowest: compound 3; then compound 4; then compounds 1 and 2 (each within the scatter of the next).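

The earlier step only exchanged pyridin-2-yl for pyridin-3-yl, so it said nothing about substitution on the ring of compound 3. Here, in this assay, a single bromo on this aromatic carbon gives a 4.8-fold higher number from compound 3 to compound 4 (0.68 log units; beyond the scatter) and weakens binding, so this position does not accept every added atom without cost. Nothing measured here offers a reason for the loss.

One group at one carbon cannot separate the effect of bromine from the effect of the place. From the compounds shown here alone, whether a fluoro or a methoxy group on this carbon, or a bromo elsewhere on this ring, would bind as compound 3 does remains open.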